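A few compounds are considered here, and "the series" means these few. Any claim that something is new, unique, unknown or untested is made for them only; others in the source may bear on it.

Values in a functional assay on 786-0 cells (Homo sapiens) for inhibition, read by sulforhodamine B assay, with a stated time of 48 h (a lower number here means a stronger inhibitor of growth, a higher number a weaker inhibitor of growth), for the measured members of the series:

Compound 1 `COc1ccc2[nH]c(-c3ccccc3)c(C=C(C#N)C#N)c2c1`: 6600 nM
Compound 2 `COc1ccc(-c2[nH]c3ccc(OC)cc3c2C=C(C#N)C#N)cc1`: 14300 nM
Compound 3 `COc1ccc2[nH]c(-c3ccccc3)c(/C=C(\C#N)S(=O)(=O)c3ccccc3)c2c1`: 6100 nM

Within the dinitrile pair, the change hydrogen in place of methoxy on an aromatic carbon gives a 2.2-fold lower number from compound 2 to compound 1 (0.34 log units; beyond the scatter). Compound 3 carries a different core; the difference between the cores of compound 3 and compound 2 is not broken down here, and the values of compound 3 and compound 1 lie within the scatter of each other.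

Compound 4 `N#C/C(=C\c1c(-c2ccccc2)[nH]c2ccccc12)S(=O)(=O)c1ccccc1` is the unmeasured member. It differs from compound 3 by hydrogen in place of methoxy on an aromatic carbon. Going by the values given here, this is the same kind of change as the one from compound 2 to compound 1, but not the same: there the methoxy left a six-membered aromatic ring of carbon only, para to a large group, whereas here it leaves a ring that is part of a fused or bridged system of two rings, meta to a fused ring and para to a fused ring. Among the compounds with values here, with only the step of a 2.2-fold lower number from compound 2 to compound 1 (0.34 log units; beyond the scatter) as a guide, and the place differing, a step of similar modest size is expected from compound 3 to compound 4, a 1.5-fold lower number from compound 3 to compound 4 (0.18 log units; within the scatter), with wide uncertainty. Compound 4 is estimated at 4000 nM, between 1500 nM and 12000 nM.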

Compound 4, concentration for 50% growth inhibition: 9200 nM
For compound 4 the middle estimate is 2.3-fold (0.36 log units) below the measured one; measured number inside the range.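

Hydrogen in place of methoxy on the core of compound 3 gives a 1.5-fold higher number from compound 3 to compound 4 (0.18 log units; within the scatter) in this assay, so this pair shows no change beyond the usual scatter. The step seen on the core of compound 2 therefore does not carry over at the same size to the core of compound 3: the same change on two cores in this assay, a 2.2-fold lower number (0.34 log units; beyond the scatter) from compound 2 to compound 1 and a 1.5-fold higher number (0.18 log units; within the scatter) from compound 3 to compound 4, 3.3-fold (0.51 log units) apart, beyond the scatter of two such steps
This does not show why the steps differ, since the two pairs differ both in the core and in the place the methoxy leaves, and two pairs cannot separate these or support a rule for the series.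

The compounds shown leave open how a methoxy at the place it holds in compound 2 would behave on the core of compound 3, and the reverse case on the core of compound 2. Also open, going by these compounds, is whether an amine, a carboxylic acid or a longer alkoxy chain at the methoxy place of compound 3 would move the number beyond the scatter.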